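Methoxy added to the phenyl of compound 2

The source may report more compounds than this note shows. Statements on the series, on what has been measured and on what is new or still open speak of the compounds shown alone.

In a toxicity assay on Huh-7 cells (Homo sapiens) for cytotoxicity, with a stated time of 3 days (on this read-out lower numbers stand for higher toxicity in this test and higher numbers for lower toxicity in this test), compound 1 `C[C@@]1(O)[C@H](O)[C@@H](CO)O[C@H]1n1cc(I)c2c(N)ncnc21` gives 19800 nM as its half-maximal cytotoxic concentration. Compound 2 `C[C@@]1(O)[C@H](O)[C@@H](CO)O[C@H]1n1cc(-c2ccccc2)c2c(N)ncnc21` is reported only as > 44000 nM and this is a limit of the assay. Going by the values given here, the sole measured step is an at least 2.2-fold higher number from compound 1 to compound 2 (0.34 log units; beyond the scatter) on placing phenyl in place of iodo on an aromatic carbon. The change to compound 3 `COc1ccc(-c2cn([C@@H]3O[C@H](CO)[C@@H](O)[C@@]3(C)O)c3ncnc(N)c23)cc1` is methoxy in place of hydrogen on an aromatic carbon on that phenyl, so phenyl to 4-methoxyphenyl, with methoxy in place of hydrogen on an aromatic carbon. Among the compounds with values here, no measured step covers a methoxy, so the iodo to phenyl step bears on it only loosely. Compound 2 gives the one anchor through the limit of > 44000 nM in this assay, at which 1 of the 2 values shown sits, and no step beyond the scatter is expected in this assay for this change. For compound 3 the estimated value is 50000 nM within an expected range of 22000 nM to 110000 nM in this read-out. The expected step is a step that the limit leaves unreadable from compound 2 to compound 3 and it remains an estimate.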

Compound 3, half-maximal cytotoxic concentration: > 44000 nM
Compound 3 gave a limit, no number; the forecaster's own chance of this, stated with the estimate: 65%; the middle value is on the limit's open side.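

In this assay compound 3 gives > 44000 nM, which is a limit of the assay and not a number. Against iodo, the 4-methoxyphenyl group shows an at least 2.2-fold higher number from compound 1 to compound 3 (0.34 log units; beyond the scatter), so a second aryl group on this aromatic carbon now lies on the lower-toxicity side of compound 1. The step between compound 2 and compound 3 cannot be read, so adding methoxy to the phenyl has no measurable size here, and the two compounds share one limit: the limit of > 44000 nM in this assay, at which 2 of the 3 values shown sit.

On these data alone, whether any substituent on this phenyl gives a number rather than a limit stays open. An amine or a carboxylic acid in the place of the methoxy would test whether the phenyl series stays at this limit in this assay.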